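The compounds below may be only part of what the source reports. "The series", "measured", "known", "first", "only" and "open" are said of these compounds alone.

Compound 1 `CCCCN(C)c1nc(C(F)(F)F)ccc1CNC(=O)C(C)c1ccc(NS(C)(=O)=O)c(F)c1` gives 0.8 nM in a functional assay on CHO-K1 cells for antagonist activity at transient receptor potential cation channel subfamily V member 1 (Homo sapiens), read by FLIPR; on this read-out higher numbers stand for weaker inhibition and lower numbers for stronger inhibition. Compound 2 `CC(C(=O)NCc1ccc(C(F)(F)F)nc1N1CCN(C)CC1)c1ccc(NS(C)(=O)=O)c(F)c1` gives 146 nM in this assay.

For the measured compounds named here, of these two numbers, compound 2 stands highest, the weaker inhibitor; its only neighbour is compound 1, reached by a 180-fold higher number from compound 1 to compound 2 (2.26 log units; beyond the scatter). Compound 3 `CC(C(=O)NCc1ccc(C(F)(F)F)nc1N1CCN(c2ccc(C(F)(F)F)cc2)CC1)c1ccc(NS(C)(=O)=O)c(F)c1` has not yet been measured. It differs from compound 2 in one place: 4-(trifluoromethyl)phenyl in place of methyl on an amine nitrogen in a ring. Going by the values given here, no measured step changes the group on this ring nitrogen, so none bears on the change directly. Among the compounds with values here, the one step recorded, a 180-fold higher number from compound 1 to compound 2 (2.26 log units; beyond the scatter), shows that what is attached at the aromatic carbon of the shared core can shift the number a great deal, and the new group sits within that same attachment. A shift beyond the scatter therefore seems likely for compound 3 in this assay, though its direction cannot be read from two compounds. Compound 3 is estimated at 40 nM, in the range 5 nM to 400 nM, an expected step of a 3.7-fold lower number from compound 2 to compound 3 (0.56 log units; beyond the scatter).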

Compound 3, inhibition constant: 2.3 nM
Estimate against measurement, compound 3: 17-fold (1.24 log units) above, outside the stated range (below it).
By their numbers in this assay, from the lowest: compound 1; then compound 3; then compound 2.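

Putting 4-(trifluoromethyl)phenyl in place of methyl on the amine nitrogen of the ring gives, in this assay, a 63-fold lower number from compound 2 to compound 3 (1.80 log units; beyond the scatter), so the group carried on this nitrogen has a large effect on the number. The earlier step showed only that 4-methylpiperazin-1-yl gave a much weaker number than butyl(methyl)amino, whereas this one shows that the six-membered ring does not fix the number by itself: its weak value in compound 2 changes greatly with the group on the ring nitrogen. No measurement available here explains the size of this change.

The compounds shown cannot separate the contribution of the aromatic ring from that of the trifluoromethyl group on it. A plain phenyl or a benzyl group on the same ring nitrogen would bear on that question.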